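The source may report more compounds than this note shows. Statements on the series, on what has been measured and on what is new or still open speak of the compounds shown alone.

Measured compounds:
- compound 1, `O=C(Nc1cccc(-n2cc(-c3ccncc3)c(-c3cc(O)cc(Cl)c3)n2)c1)Nc1ccc(Cl)c(Cl)c1`, giving 6.85% in a functional assay on ACHN cells (Homo sapiens) for inhibition, read by sulforhodamine B assay, with a stated time of 48 h, tested at 10 uM; on this read-out higher numbers stand for a weaker effect at the one concentration tested and lower numbers for a stronger effect
- compound 2, `COc1cc(Cl)cc(-c2nn(-c3cccc(NC(=O)Nc4cc(C(F)(F)F)cc(C(F)(F)F)c4)c3)cc2-c2ccncc2)c1`, giving 10.3% in this assay

Compound 2 has the highest of these two numbers in this assay, yet its nearest neighbour, compound 1, sits only a little lower, within the scatter, so the two cannot be ordered. Compound 3, `COc1cc(Cl)cc(-c2nn(-c3cccc(NC(=O)Nc4cccc(C(F)(F)F)c4)c3)cc2-c2ccncc2)c1`, differs from compound 2 in one place: hydrogen in place of trifluoromethyl on an aromatic carbon. Within the data shown here, no measured pair shows such a change, so the size of the step in this assay is unknown; it is expected to stay small and within the scatter, in either direction. Compound 3 is therefore estimated at 14%, between 4% and 35%, a step of a number 3.7 percentage points higher from compound 2 to compound 3 (within the scatter).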

Compound 3, a percentage reported as activity, at one concentration (the size of the read-out at that concentration, not a potency): 5.44%
Compound 3: the middle estimate sits 8.6 percentage points above what was measured; measured number inside the range.
By their numbers in this assay, from the lowest: compounds 3, 1 and 2 (each within the scatter of the next).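

At this position, one trifluoromethyl group can give way to hydrogen while the other trifluoromethyl group stays, and the read-out in this assay does not move beyond the scatter (a number 4.9 percentage points lower from compound 2 to compound 3 (within the scatter)). Among these compounds, this is the first single change the compounds show at this place, and its size is small. Nothing measured bears on the reason for this. The compounds shown leave open whether the remaining trifluoromethyl group can also give way to hydrogen. They also leave open whether an amine or a carboxylic acid on this aromatic carbon would move the number beyond the scatter.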